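A few compounds are considered here, and "the series" means these few. Any claim that something is new, unique, unknown or untested is made for them only; others in the source may bear on it.

In a functional assay on QG-56 cells (Homo sapiens) for antiproliferative activity (on this read-out lower numbers stand for stronger inhibition and higher numbers for weaker inhibition), compound 1 `COc1cccc(-c2cc([N+](=O)[O-])cc3cc(C(O)(c4ccc(C#N)cc4)c4cncn4C)oc23)c1` gives 38.8 nM, compound 3 `COc1ccc(-c2cc([N+](=O)[O-])cc3cc(C(O)(c4ccc(C#N)cc4)c4cncn4C)oc23)cc1` gives 36 nM and compound 2 `Cn1cncc1C(O)(c1ccc(C#N)cc1)c1cc2cc([N+](=O)[O-])cc(-c3ccccc3F)c2o1` gives 89.5 nM. Compound 1 is thus the second highest of the three numbers, level with compound 3: a 1.1-fold lower number from compound 1 to compound 3 (0.03 log units; within the scatter). Compound 4 `COc1cccc(-c2cc(C=O)cc3cc(C(O)(c4ccc(C#N)cc4)c4cncn4C)oc23)c1` carries formyl in place of nitro on an aromatic carbon, meta to a 3-methoxyphenyl group (formyl in place of nitro on an aromatic carbon). Going by the values given here, no measured step covers this exchange. All three keep nitro and swap the phenyl group instead: besides the step already given, they show a 2.3-fold higher number from compound 1 to compound 2 (0.36 log units; beyond the scatter) and a 2.5-fold lower number from compound 2 to compound 3 (0.40 log units; beyond the scatter). Among the compounds with values here, those steps suggest only that single changes here have moved the number modestly. The estimated change is small, a 1.4-fold higher number from compound 1 to compound 4 (0.15 log units; within the scatter). Compound 4 is expected at 55 nM, within an estimated range of 15 nM to 200 nM.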

Compound 4, half-maximal inhibitory concentration: 15.2 nM
For compound 4 the middle estimate is 3.6-fold (0.56 log units) above the measured one; low and high end bracket the measured number.
By their numbers in this assay, from the lowest: compound 4; then compounds 3 and 1 (each within the scatter of the next); then compound 2.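

In this assay, going by these compounds alone, the earlier compounds all kept nitro and varied only the phenyl group, so this is the first view of the position itself. Formyl in place of nitro, with the 3-methoxyphenyl group kept, gives a 2.6-fold lower number from compound 1 to compound 4 (0.41 log units; beyond the scatter), which shows that nitro is not required here for a low number. Nothing available bears on the cause of this step. Going by these compounds, whether the exchange holds with the phenyl groups of compound 2 and compound 3 remains open. So does how a carboxylic acid, an amine or a hydroxymethyl group would fare on this aromatic carbon.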